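Triazole-aryl swap on a chalcone scaffold

The compounds below may be only part of what the source reports. "The series", "measured", "known", "first", "only" and "open" are said of these compounds alone.

Measured compounds:
compound 1 `COc1ccc(/C=C/C(=O)c2cccc(N=[N+]=[N-])c2)cc1O`: 1960 nM
compound 2 `COc1cc(/C=C/C(=O)c2cccc(-n3cc(-c4ccc(F)cc4)nn3)c2)ccc1O`: 6450 nM

In a functional assay on RAW264.7 cells (Mus musculus) for inhibition, with a stated time of 4 days (a lower number here means a stronger inhibitor, a higher number a weaker inhibitor), compound 2 gives 6450 nM, the highest of the two numbers; compound 1 gives 1960 nM, a gap beyond the scatter. Compound 3 `COc1cc(/C=C/C(=O)c2cccc(-n3cc(-c4ccccc4C(F)(F)F)nn3)c2)ccc1O` carries 2-(trifluoromethyl)phenyl in place of 4-fluorophenyl on an aromatic carbon. Among the compounds with values here, no measured pair shows this kind of change, so the step from compound 2 to compound 3 is a guess: the expectation is a step near zero, at most a modest one in either direction, a 1.1-fold higher number from compound 2 to compound 3 (0.04 log units; within the scatter). Compound 3 is estimated to give 7000 nM in this assay, with a range from 2500 nM to 20000 nM.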

Compound 3, half-maximal inhibitory concentration: 5070 nM
Compound 3: middle estimate off by 1.4-fold (0.14 log units), on the high side; the measured number falls inside the stated range.
By their numbers in this assay, from the lowest: compound 1; then compounds 3 and 2 (each within the scatter of the next).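

In this assay, putting 2-(trifluoromethyl)phenyl in place of 4-fluorophenyl on the five-membered aromatic ring with 3 nitrogen gives a 1.3-fold lower number from compound 2 to compound 3 (0.10 log units; within the scatter), so at this position the two groups cannot be told apart, though they differ in their fluorine count and heavy-atom count. Nothing available explains why the two read alike. Both groups here are fluorinated phenyl rings, so the position has only been probed narrowly. On these data alone, whether a plain phenyl ring, or a phenyl ring bearing an amine or a carboxylic acid, would also read alike remains open.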